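The source may report more compounds than this note shows. Statements on the series, on what has been measured and on what is new or still open speak of the compounds shown alone.

Measured in a functional assay on SGC-7901 cells (Homo sapiens) for antiproliferative activity, read by MTT assay, with a stated time of 72 h (a higher number here means a weaker inhibitor, a lower number a stronger inhibitor), as follows:
Compound 1 `COc1cc(-n2cnc3ccc(-c4ccccc4)cc32)cc(OC)c1OC` gives 290 nM
Compound 2 `COc1cc(-n2cnc3ccc(-c4cccc(C)c4C)cc32)cc(OC)c1OC` gives 3040 nM
Compound 3 `COc1cc(-n2cnc3ccc(-c4ccc(Cl)cc4Cl)cc32)cc(OC)c1OC` gives > 10000 nM

Compound 3 stands at > 10000 nM as a limit of the assay and not a number. Compound 4 `COc1ccc(-c2ccc3ncn(-c4cc(OC)c(OC)c(OC)c4)c3c2)cc1` carries 4-methoxyphenyl in place of 2,4-dichlorophenyl on an aromatic carbon with the shared core unchanged. For the measured compounds named here, three measured steps bear on this, namely a 10-fold higher number from compound 1 to compound 2 (1.02 log units; beyond the scatter) and an at least 34-fold higher number from compound 1 to compound 3 (1.53 log units; beyond the scatter) as large changes and an at least 3.2-fold higher number from compound 2 to compound 3 (0.51 log units; beyond the scatter) as an at least modest one. The group at this place therefore moves the number strongly, and 2,4-dichlorophenyl gave the highest reading of the three. Removing it is expected to bring an at least 14-fold lower number from compound 3 to compound 4 (1.15 log units; beyond the scatter) as a large step toward lower numbers in this assay for this series. The estimate for compound 4 is 700 nM with an expected range from 120 nM to 5000 nM in this assay.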

Compound 4, half-maximal inhibitory concentration: 82 nM
Estimate against measurement, compound 4: 8.5-fold (0.93 log units) above, outside the stated range (below it).
By their numbers in this assay, from the lowest: compound 4; then compound 1; then compound 2. At a limit, above all of these: compound 3.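

In this assay, a substituted phenyl at this position now reads lower than plain phenyl, with a 3.5-fold lower number from compound 1 to compound 4 (0.55 log units; beyond the scatter), so substitution here is not uniformly adverse; compound 2 and compound 3 go the other way. The choice of substituted phenyl carries a wide span, with a 37-fold lower number from compound 2 to compound 4 (1.57 log units; beyond the scatter) and an at least 120-fold lower number from compound 3 to compound 4 (2.08 log units; beyond the scatter). That last step is only a bound, and compound 3 stands at a limit of the assay: the limit of > 10000 nM in this assay, at which 1 of the 4 values shown sits.

From the compounds shown here alone, whether the lower number follows from methoxy itself or from any single group on the phenyl stays open. A hydroxy, an amine or a lone chlorine in the same place would bear on that.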